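This account rests on a few compounds, and the source may have more. Where it says the series, first, only, none or still open, it means among the compounds named here.

Compound 1 `COc1ccc(-c2cc(/C=C/C(=O)c3ccc(N)cc3)[nH]n2)cc1` is the starting point here. In a functional assay on MDA-MB-231 cells (Homo sapiens) for cytotoxicity, read by sulforhodamine B assay, with a stated time of 48 h, tested at 100 uM (on this read-out higher numbers stand for a weaker effect at the one concentration tested and lower numbers for a stronger effect), compound 1 gives -65%, the lowest of the three numbers shown. Its nearest neighbour is compound 3 `COc1cc(-c2cc(/C=C/C(=O)c3ccc(F)c(F)c3)[nH]n2)cc(OC)c1OC`, which gives -49%, and furthest away is compound 2 `COc1cc(-c2cc(/C=C/C(=O)c3ccc(Cl)c(Cl)c3)[nH]n2)cc(OC)c1OC`, which gives 2%; both sit beyond the scatter from compound 1.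

Compound 4 `COc1ccc(-c2cc(/C=C/C(=O)c3ccc(N)cc3)[nH]n2)cc1OC` differs from compound 1 in one place: methoxy in place of hydrogen on an aromatic carbon. Within the data shown here, the one measured step, a number 51 percentage points lower from compound 2 to compound 3 (beyond the scatter), concerns the ring on the carbonyl carbon, not the ring that carries the methoxy group, so it does not bear directly on this change. Compound 2 and compound 3 carry three methoxy groups on that ring, where compound 1 carries one; compound 4 lies between these with two. Because compound 1 at -65% and compound 3 at -49% both show strong effects with different numbers of methoxy groups, a second methoxy group is not expected to move the number beyond the scatter in either direction. Compound 4 is therefore estimated to stay close to compound 1, with a step of a number 5 percentage points higher from compound 1 to compound 4 (within the scatter) expected. Compound 4 is expected to give about -60%, somewhere between -85% and -30%.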

Compound 4, a percentage reported as activity, at one concentration (the size of the read-out at that concentration, not a potency): -77%
The estimate for compound 4 lay 17 percentage points above the measured number; measured number inside the range.
By their numbers in this assay, from the lowest: compound 4; then compound 1; then compound 3; then compound 2.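

Adding a methoxy group on this aromatic carbon, ortho to a methoxy group and meta to a large group, gives in this assay a clear change: a number 12 percentage points lower from compound 1 to compound 4 (beyond the scatter). On this read-out the lower number stands for a stronger effect at the one concentration tested, so this carbon accepts a second methoxy group and the effect grows modestly, a direct reading that the earlier step on the ring attached to the carbonyl carbon could not provide. Nothing measured here explains why this added methoxy group lowers the number.

The compounds shown leave open whether this result belongs to methoxy itself, since a hydroxy group, an ethoxy group or a single fluorine atom on the same carbon would be needed for comparison. They also leave open whether the same added methoxy group would lower the number by a similar amount in a compound with a different group on the ring attached to the carbonyl carbon, such as 3,4-difluorophenyl in place of the ring carrying the amine.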